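A few compounds are considered here, and "the series" means these few. Any claim that something is new, unique, unknown or untested is made for them only; others in the source may bear on it.

In an in vitro functional assay on HEK285-7 cells for antagonist activity at prostaglandin D2 receptor 2 (Homo sapiens), read by BRET and beta-arrestin recruitment (a higher number here means a larger maximal response, a lower number a smaller maximal response), the measured compounds give:

compound 1, `CS(=O)(=O)Nc1cccc(-c2nc(C(c3ccc(F)cc3)c3ccc(F)cc3)sc2CC(=O)O)c1`: 80%
compound 2, `O=C(O)Cc1sc(C(c2ccc(F)cc2)c2ccc(F)cc2)nc1-c1cccc(F)c1`: 80%
compound 3, `O=C(O)Cc1sc(C(c2ccc(F)cc2)c2ccc(F)cc2)nc1-c1ccccc1`: 80%

Compound 3 stands level with compounds 1 and 2 at the digits shown; no change at the digits printed from compound 1 to compound 3 (within the scatter) and no change at the digits printed from compound 2 to compound 3 (within the scatter) both lie within the scatter, as does no change at the digits printed from compound 1 to compound 2 (within the scatter). The unmeasured compound 4, `Cc1cc(-c2nc(C(c3ccc(F)cc3)c3ccc(F)cc3)sc2CC(=O)O)cnc1N`, differs from compound 3 in one place: 6-amino-5-methylpyridin-3-yl in place of phenyl on an aromatic carbon. The three measured steps all concern the same aromatic ring that is replaced here, varying a group on it between methanesulfonamido, fluoro and hydrogen, and none of them moved the maximal response beyond the scatter. For the measured compounds named here, they bear on the step to compound 4 only indirectly, since the change here exchanges the ring itself rather than a group on it, and no measured step covers such an exchange. The expected step is therefore within the scatter, no change at the digits printed from compound 3 to compound 4 (within the scatter), resting on the flat behaviour seen so far. Compound 4 is estimated at 80%, with a range from 62% to 95%. Going by the values given here, the range is kept wide: no measured step covers an exchange of the ring itself, so this kind of change is untested.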

Compound 4, largest response reached (reported as efficacy), in percent of the reference or control that the assay uses: 80%
Beside the measured number, compound 4's estimate shows no gap at the digits printed; the range from low to high includes it.
By their numbers in this assay, from the lowest: compounds 1, 2, 3 and 4 (each within the scatter of the next).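

In this assay an exchange of the ring itself, on an aromatic carbon next to the ring nitrogen, now has a reading: no change at the digits printed from compound 3 to compound 4 (within the scatter) for 6-amino-5-methylpyridin-3-yl in place of phenyl. The substituted rings give the same picture, with no change at the digits printed from compound 2 to compound 4 (within the scatter) for the replacement of 3-fluorophenyl and no change at the digits printed from compound 1 to compound 4 (within the scatter) for the replacement of 3-(methanesulfonamido)phenyl, so the flat behaviour at this position now extends to a ring with 1 hetero atom that brings 1 hydrogen-bond donor and 2 hydrogen-bond acceptors. No supporting data bear on why the maximal response stays level across these changes.

Still open, going by these compounds, is whether an open-chain alkyl amine at this position would leave the reading level. The compounds shown also leave open whether a longer carboxylic acid chain in place of the carboxymethyl group would do so.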